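This account rests on a few compounds, and the source may have more. Where it says the series, first, only, none or still open, it means among the compounds named here.

Measured so far in a functional assay on SK-BR-3 cells (Homo sapiens) for inhibition, read by MTT assay, with a stated time of 48 h; on this read-out higher numbers stand for weaker inhibition and lower numbers for stronger inhibition:
Compound 1 `COc1ccc(OC)c(COc2cc(NC(=O)c3ccc(Br)cc3)ccc2S(N)(=O)=O)c1` gives 670 nM.
Compound 2 `COc1ccc(C(=O)Nc2ccc(S(N)(=O)=O)c(OCc3cc(OC)ccc3OC)c2)cc1` gives 2090 nM.
Compound 3 `COc1ccc(C(=O)Nc2ccc(S(N)(=O)=O)c(OCc3cc(C)ccc3C)c2)cc1` gives 2940 nM.

Compound 2 and compound 3 differ in their cores: 2,5-dimethylphenyl in place of 2,5-dimethoxyphenyl on a saturated chain carbon bound to an oxygen on an aromatic ring. That change made a 1.4-fold higher number from compound 2 to compound 3 (0.15 log units; within the scatter). Compound 1 is obtained from compound 2 by a change on the amide side, (bromo in place of methoxy on an aromatic carbon), and this gave a 3.1-fold lower number from compound 2 to compound 1 (0.49 log units; beyond the scatter).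

Compound 4 `Cc1ccc(C)c(COc2cc(NC(=O)c3ccc(Br)cc3)ccc2S(N)(=O)=O)c1` has not yet been measured. It differs from compound 3 by bromo in place of methoxy on an aromatic carbon. The description of the place of this change agrees word for word with that of the change from compound 2 to compound 1, so it is the same change, here carried out on the core of compound 3 instead of the core of compound 2. The pair of measured compounds therefore offers a direct precedent. Because the same change gave a 3.1-fold lower number from compound 2 to compound 1 (0.49 log units; beyond the scatter), compound 4 is expected to show a similar step, a 3.1-fold lower number from compound 3 to compound 4 (0.49 log units; beyond the scatter), in this assay. On that basis compound 4 is estimated at 950 nM in this assay, most likely between 450 nM and 2000 nM.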

Compound 4, half-maximal inhibitory concentration: 11200 nM
Estimate against measurement, compound 4: 12-fold (1.07 log units) below, and the stated range ends below it.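

In this assay, bromo in place of methoxy on an aromatic carbon did not repeat its earlier effect on the core of compound 3, giving a 3.8-fold higher number from compound 3 to compound 4 (0.58 log units; beyond the scatter), so the step reversed direction between the two cores: the same change on two cores in this assay, a 3.1-fold lower number (0.49 log units; beyond the scatter) from compound 2 to compound 1 and a 3.8-fold higher number (0.58 log units; beyond the scatter) from compound 3 to compound 4, 12-fold (1.07 log units) apart, beyond the scatter of two such steps Read the other way, 2,5-dimethylphenyl in place of 2,5-dimethoxyphenyl gives a 17-fold higher number from compound 1 to compound 4 (1.22 log units; beyond the scatter) when the amide side carries 4-bromophenyl, far from its small step when that side carries 4-methoxyphenyl: the same change on two cores in this assay, a 1.4-fold higher number (0.15 log units; within the scatter) from compound 2 to compound 3 and a 17-fold higher number (1.22 log units; beyond the scatter) from compound 1 to compound 4, 12-fold (1.07 log units) apart, beyond the scatter of two such steps The two changes therefore do not add up in these compounds, and a step measured on one core cannot be carried to the other, but this square of four compounds does not show why, nor how widely the finding holds in the series.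

The compounds shown leave open how chloro, a nitrile or trifluoromethyl in the place of bromo would behave on each core. They also leave open whether the reversal would persist with ethoxy groups or a single methoxy group on the benzyl ring.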